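The source may report more compounds than this note shows. Statements on the series, on what has been measured and on what is new or still open speak of the compounds shown alone.

Working notes on the butynyl-linked series.

Compound 1 `COC(=O)N(C)CC#CCn1ccnc1` in a functional assay on the whole organism for agonist activity, with Mus musculus as the target (a lower number here means that less compound is needed, a higher number that more compound is needed for the effect), gives 4.5 mg/kg. Compound 2 `COC(=O)N(C)CC#CCn1cncc1C` carries methyl in place of hydrogen on an aromatic carbon. For compound 2 this assay reports only a limit, > 100 mg/kg. The step is an at least 22-fold higher number from compound 1 to compound 2 (1.34 log units; beyond the scatter), and it runs into (the limit of > 100 mg/kg in this assay, at which 1 of the 3 values shown sits), so its full size is not known.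

Compound 3 `O=C1OCCN1CC#CCn1ccnc1` has a different core; the difference between the core of compound 1 and that of compound 3 is not broken down here. In this assay compound 3 gives 2 mg/kg, the lowest number of the two measured, and beyond the scatter from compound 1.

Compound 4 `Cc1cncn1CC#CCN1CCOC1=O`, not yet measured, carries methyl in place of hydrogen on an aromatic carbon, the same change as from compound 1 to compound 2, at a place described in identical words. A large rise is expected from compound 3 to compound 4, resting on an at least 22-fold higher number from compound 1 to compound 2 (1.34 log units; beyond the scatter), with the chance that the assay again reports only a limit. The step expected is a 40-fold higher number from compound 3 to compound 4 (1.60 log units; beyond the scatter). For compound 4 the expected value is 80 mg/kg, between 20 mg/kg and 300 mg/kg.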

Compound 4, dose for half-maximal effect: > 100 mg/kg
Compound 4 was reported as a limit; the forecaster's own chance of this, stated with the estimate: 50%; middle value at least 1.2-fold (0.09 log units) from the limit.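

In this assay, methyl in place of hydrogen on an aromatic carbon gives a large rise on a second core, with an at least 50-fold higher number from compound 3 to compound 4 (1.69 log units; beyond the scatter), so the direction of the change carries over from the core of compound 1 to the core of compound 3: the same change on two cores in this assay, an at least 22-fold higher number (1.34 log units; beyond the scatter) from compound 1 to compound 2 and an at least 50-fold higher number (1.69 log units; beyond the scatter) from compound 3 to compound 4; the limit leaves it open whether they differ. Compound 4 is reported only as a limit, > 100 mg/kg, and the step to compound 2 also ends at a limit: the limit of > 100 mg/kg in this assay, at which 2 of the 4 values shown sit. The two compounds therefore show that the rise recurs on both cores, but not how large either rise is, whether the two differ in size, or whether it would recur on any core beyond these two.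

As far as these compounds go, it remains open whether the rise belongs to methyl in particular, or whether an ethyl group or a chlorine atom on the same aromatic carbon would give a similar number in this assay. Also open, from the compounds shown here alone, is whether a third core, for example one carrying a tertiary amine, would follow the same direction.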